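Trichlorophenyl variant of the bromophenyl enone series

A few compounds are considered here, and "the series" means these few. Any claim that something is new, unique, unknown or untested is made for them only; others in the source may bear on it.

Measured compounds:
- compound 1 `COc1ccc(/C=C(/SCc2ccc(Cl)cc2)C(=O)c2ccc(Br)cc2)cc1`: 10000 nM
- compound 2 `CN(C)c1ccc(/C=C(/SCc2ccc(Cl)cc2)C(=O)c2ccc(Br)cc2)cc1`: 10000 nM
- compound 3 `COc1ccc(/C=C(/SCc2ccc(Cl)cc2)C(=O)c2ccc(Br)cc2)cc1O`: 1000 nM

In a functional assay on DU-145 cells (Homo sapiens) for inhibition, read by trypan blue exclusion, with a stated time of 96 h (a higher number here means a weaker inhibitor of growth, a lower number a stronger inhibitor of growth), compound 3 gives the lowest number of the three; compound 1 and compound 2 show the same number as each other, and the step of no change at the digits printed from compound 1 to compound 2 (within the scatter) is within the scatter. The gain came with the hydroxy, as a 10-fold lower number from compound 1 to compound 3 (1.00 log units; beyond the scatter) and a 10-fold lower number from compound 2 to compound 3 (1.00 log units; beyond the scatter) show.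

Compound 4 `O=C(/C(=C\c1cc(Cl)cc(Cl)c1Cl)SCc1ccc(Cl)cc1)c1ccc(Br)cc1` differs from compound 3 by 2,3,5-trichlorophenyl in place of 3-hydroxy-4-methoxyphenyl on a double-bonded chain carbon bound to a double-bonded chain carbon. The change removes the hydroxy group that separates compound 3 from compound 1 and compound 2, and the new ring carries no donor or acceptor. Among the measured compounds shown here, no measured pair tests a trichlorophenyl in this position. The nearest bearing steps, a 10-fold lower number from compound 1 to compound 3 (1.00 log units; beyond the scatter) and a 10-fold lower number from compound 2 to compound 3 (1.00 log units; beyond the scatter), ran in the favourable direction with the hydroxy; its loss is therefore expected to give a higher number, estimated as an 8.0-fold higher number from compound 3 to compound 4 (0.90 log units; beyond the scatter) in this assay. Compound 4 is expected at 8000 nM, within 2500 nM to 30000 nM.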

Compound 4, concentration for 50% growth inhibition: 1000 nM
Beside the measured number, compound 4's estimate is 8.0-fold (0.90 log units) above it, outside the stated range (below it).
By their numbers in this assay, from the lowest: compounds 3 and 4 (each within the scatter of the next); then compounds 1 and 2 (each within the scatter of the next).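

In this assay the replacement gives no change at the digits printed from compound 3 to compound 4 (within the scatter), so the hydroxy is not required at this position for the lower number. The same ring gives a 10-fold lower number from compound 2 to compound 4 (1.00 log units; beyond the scatter) and a 10-fold lower number from compound 1 to compound 4 (1.00 log units; beyond the scatter), so a 2,3,5-trichlorophenyl with no hydrogen-bond donors or acceptors also separates from the two weaker compounds. No supporting data explain why these two different rings match.

Still open, as far as these compounds go, is whether a single chlorine on this ring does the same. Also open, from the compounds shown here alone, is how a ring bearing a carboxylic acid or an amine would behave here.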